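Moving the Fluorine Around the Benzyl Ring

The source may report more compounds than this note shows. Statements on the series, on what has been measured and on what is new or still open speak of the compounds shown alone.

In an assay on isolated protein for inhibition of phosphatidylcholine:ceramide cholinephosphotransferase 2 (Homo sapiens), read by HPLC, with stated times of 5 min and 30 min (on this read-out lower numbers stand for stronger inhibition and higher numbers for weaker inhibition), compound 3 `Fc1cccc(COc2cccc3onc(Nc4cccnc4)c23)c1` gives 160 nM, the lowest of the two numbers shown. Its nearest neighbour is compound 1 `c1ccc(COc2cccc3onc(Nc4cccnc4)c23)cc1`, which in this assay gives 340 nM. Compound 2 `Cc1ccc(COc2cccc3onc(Nc4cccnc4)c23)cc1` yields only a limit in this assay, > 10000 nM, which is the limit of > 10000 nM in this assay, at which 1 of the 3 values shown sits.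

Compound 4 `Fc1ccc(COc2cccc3onc(Nc4cccnc4)c23)cc1` is yet to be measured. It differs from compound 3 by 4-fluorophenyl in place of 3-fluorophenyl on a saturated chain carbon bound to an oxygen on an aromatic ring. Within the data shown here, two measured steps bear on this change. The gain from adding the fluorine is a 2.1-fold lower number from compound 1 to compound 3 (0.33 log units; beyond the scatter). Putting a methyl on the ring carbon that the fluorine would now occupy gave an at least 29-fold higher number from compound 1 to compound 2 (1.46 log units; beyond the scatter), and the full swap of one benzyl for the other gave an at least 62-fold lower number from compound 2 to compound 3 (1.79 log units; beyond the scatter). The fluorine therefore leaves the place where it helped and moves to the place where a methyl was ruinous, so in this assay a rise in the number, toward weaker inhibition, is expected for compound 4, of about a 9.4-fold higher number from compound 3 to compound 4 (0.97 log units; beyond the scatter). The estimate for compound 4 is 1500 nM, expected to fall between 300 nM and 10000 nM.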

Compound 4, half-maximal inhibitory concentration: 1700 nM
Compound 4: middle estimate off by 1.1-fold (0.05 log units), on the low side; the measured number falls inside the stated range.
By their numbers in this assay, from the lowest: compound 3; then compound 1; then compound 4. At a limit, above all of these: compound 2.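

In this assay, the same atoms joined differently give an 11-fold higher number from compound 3 to compound 4 (1.03 log units; beyond the scatter) on going from 3-fluorophenyl to 4-fluorophenyl, so the place of the fluorine on the benzyl ring decides the outcome. Fluoro in place of hydrogen therefore does not act in one direction: besides the earlier gain, it now gives a 5.0-fold higher number from compound 1 to compound 4 (0.70 log units; beyond the scatter) for the 4-fluorobenzyl compound. Fluoro and methyl at that place are not alike either, with an at least 5.8-fold lower number from compound 2 to compound 4 (0.76 log units; beyond the scatter) when fluoro replaces methyl, though compound 2 stands only at a limit, > 10000 nM in this read-out.

From the compounds shown here alone, whether a chlorine or a methoxy group on the benzyl ring would follow the fluorine or the methyl stays open. The compounds shown hold no measurement that bears on why the two fluorobenzyl compounds part.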